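Triazole Aryl Swap: From Methoxyphenyl to Sulfamoylphenyl

The source may report more compounds than this note shows. Statements on the series, on what has been measured and on what is new or still open speak of the compounds shown alone.

Measured so far:
Compound 1 `N#CC1=C(N)Oc2c(c3nc4ccccc4nc3c3ccccc23)C12C(=O)N(Cc1cnnn1-c1cccc(Br)c1)c1ccccc12` in an ADME assay on HUVEC cells (Homo sapiens) for antiproliferative activity, read by MTT assay, with a stated time of 48 h; a lower number here means a stronger inhibitor, a higher number a weaker inhibitor: > 50000 nM, a limit of the assay.
Compound 2 `COc1ccccc1-n1nncc1CN1C(=O)C2(C(C#N)=C(N)Oc3c2c2nc4ccccc4nc2c2ccccc32)c2ccccc21` in this assay: > 50000 nM, a limit of the assay.

Compound 2 stands only at a limit of the assay, > 50000 nM, with no number behind it. For the measured compounds named here, the one measured step, a step that the two limits leave unreadable from compound 1 to compound 2, cannot be read in size or direction because of the limit of > 50000 nM in this assay, at which 2 of the 2 values shown sit. Both measured compounds sit at that same limit, so nothing on record shows how a change of the group on the aromatic nitrogen moves the read-out.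

Compound 3 `N#CC1=C(N)Oc2c(c3nc4ccccc4nc3c3ccccc23)C12C(=O)N(Cc1cnnn1-c1ccc(S(N)(=O)=O)cc1)c1ccccc12` differs from compound 2 by 4-sulfamoylphenyl in place of 2-methoxyphenyl on an aromatic nitrogen. With no readable step to draw on, the expectation rests on the two limits alone. Compound 3 is estimated at 80000 nM, between 20000 nM and 300000 nM, and most likely reported as a limit once more. The expected step that the limit leaves unreadable from compound 2 to compound 3 is accordingly nothing beyond the scatter.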

Compound 3, half-maximal inhibitory concentration: > 50000 nM
Compound 3: a limit, no number (the forecaster's own chance of this, stated with the estimate: 85%); the middle value is on the limit's open side.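

Neither the step from compound 2 to compound 3 nor the step from compound 1 to compound 3 can be read in size or direction, because all three compounds share one limit: the limit of > 50000 nM in this assay, at which 3 of the 3 values shown sit. On these data alone, whether changing the group on the aromatic nitrogen moves the read-out in this assay at all stays open.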